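This account rests on a few compounds, and the source may have more. Where it says the series, first, only, none or still open, it means among the compounds named here.

Measured values in a functional assay on P388 cells (Mus musculus) for cytotoxicity, read by MTT assay, with a stated time of 72 h; a lower number here means a stronger inhibitor, a higher number a weaker inhibitor:

compound 1 `Cc1ccc(S(=O)(=O)Nc2cccc3[nH]nc(Br)c23)cc1` — 53900 nM
compound 2 `CCOc1ccc(NS(=O)(=O)c2ccc(C)cc2)c2c(Br)n[nH]c12` — 5210 nM
compound 3 `C=CCn1cc2ccc(NS(=O)(=O)c3ccc(C)cc3)cc2n1` — 4410 nM

Compound 2 differs from compound 1 by ethoxy in place of hydrogen on an aromatic carbon; this gave a 10-fold lower number from compound 1 to compound 2 (1.01 log units; beyond the scatter). The difference between the core of compound 3 and the core of compound 1 is not broken down here; compound 3 and compound 2 lie within the scatter of each other in this assay.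

Compound 4 `C=CCn1cc2ccc(NS(=O)(=O)c3ccc(C)cc3)c(OCC)c2n1` carries ethoxy in place of hydrogen on an aromatic carbon. This is the same kind of change as in compound 2, but the place differs: in compound 2 it is para to a large group, in compound 4 ortho to a large group. Among the compounds with values here, only one step of this change is known, so no steady effect can be claimed. A smaller step than in compound 2 is expected, a 2.9-fold lower number from compound 3 to compound 4 (0.47 log units; beyond the scatter), because the surroundings differ and only a 10-fold lower number from compound 1 to compound 2 (1.01 log units; beyond the scatter) is available. Compound 4 is expected to give 1500 nM in this assay, between 400 nM and 5000 nM.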

Compound 4, half-maximal inhibitory concentration: 68900 nM
Compound 4: the middle estimate sits 46-fold (1.66 log units) below what was measured; measured number above the stated range.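

In this assay, ethoxy in place of hydrogen on an aromatic carbon gives a 16-fold higher number from compound 3 to compound 4 (1.19 log units; beyond the scatter), opposite in direction to the earlier step on the other core: the same change on two cores in this assay, a 10-fold lower number (1.01 log units; beyond the scatter) from compound 1 to compound 2 and a 16-fold higher number (1.19 log units; beyond the scatter) from compound 3 to compound 4, 160-fold (2.21 log units) apart, beyond the scatter of two such steps. In this series, therefore, the effect of this change on one core cannot be carried over to the other, not even as to direction. The two steps do not show whether the core or the place of the ethoxy sets the outcome, since both differ between them, and they give no cause for the reversal.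

Going by these compounds, it remains open whether methoxy, a longer alkoxy chain or an amine on the same aromatic carbon of compound 3 would follow compound 4. Also open, on these data alone, is how ethoxy would behave elsewhere on that ring.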